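This account rests on a few compounds, and the source may have more. Where it says the series, first, only, none or still open, it means among the compounds named here.

Measured so far in a functional assay on the whole organism (strain Wistar) for inhibition, with Rattus norvegicus as the target, read by paw edema, with stated times of 60 min and 1 h, at a dose of 100 mg/kg by the oral route; on this read-out lower numbers stand for less inhibition and higher numbers for more inhibition at the one dose given (going by the name of the read-out):
compound 1, `COc1cc2c(cc1OC)C(CC(=O)O)CC2`, gives 18.8%
compound 2, `CCCNC(=O)CC1CCc2cc(OC)c(OC)cc21`, gives 18.8%

Among the compounds with values here, compound 2 stands level with compound 1 on these numbers: the one measured step, no change at the digits printed from compound 1 to compound 2 (within the scatter), lies within the scatter, so nothing can be said about an order between them. The unmeasured compound 3, `CCCCCCNC(=O)CC1CCc2cc(OC)c(OC)cc21`, differs from compound 2 by propyl in place of hydrogen on a saturated chain carbon, three bonds along the chain from an amide-type nitrogen; read one bond further out, the same change is propyl to hexyl on the amide-type nitrogen. Within the data shown here, no measured step touches the length of this chain; the only step available, from compound 1 to compound 2, replaces hydroxy with propylamino on the carbonyl carbon and shows no change beyond the scatter. That step bears on compound 3 only in that it shows a change on the amide side of the molecule leaving the number in this assay level. Compound 3 is therefore expected to give about 19% in this assay, with a range from 8% to 32%, which means an expected step of a number 0.2 percentage points higher from compound 2 to compound 3 (within the scatter).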

Compound 3, a percentage reported as inhibition, in the whole organism at one dose (the size of the read-out at that dose, not a potency): 47.6%
Compound 3: the middle estimate sits 28.6 percentage points below what was measured, outside the stated range (above it).
By their numbers in this assay, from the lowest: compounds 1 and 2 (each within the scatter of the next); then compound 3.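

In this assay, the length of the chain on the amide-type nitrogen does register: propyl to hexyl there, which is propyl in place of hydrogen on a saturated chain carbon, three bonds along the chain from an amide-type nitrogen, gives a number 28.8 percentage points higher from compound 2 to compound 3 (beyond the scatter). Hexylamino in place of hydroxy on the carbonyl carbon gives a number 28.8 percentage points higher from compound 1 to compound 3 (beyond the scatter), while propylamino in that same place gave no change at the digits printed from compound 1 to compound 2 (within the scatter), so among the compounds shown, replacing the hydroxy moves the number beyond the scatter only with the hexyl chain. Nothing available here accounts for the higher number with the longer chain.

The compounds shown leave open where between propyl and hexyl the rise sets in, as butyl and pentyl on the amide-type nitrogen would show, and whether a longer chain such as octyl raises the number further or brings it back down. They also leave open whether chain length alone carries the step, or whether a branched chain such as isohexyl or a chain ending in a phenyl ring would read the same at this position.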